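Compound 2 and its unmeasured triazole, compound 4

A few compounds are considered here, and "the series" means these few. Any claim that something is new, unique, unknown or untested is made for them only; others in the source may bear on it.

In a functional assay on SW480 cells (Homo sapiens) for antiproliferative activity, read by MTT assay, with a stated time of 48 h (on this read-out lower numbers stand for stronger inhibition and higher numbers for weaker inhibition), compound 1 `CCCCCCCCCC(CCO)n1cnc2c(Cl)ncnc21` gives 1150 nM and compound 2 `CCCCCCCCCC(CCN=[N+]=[N-])n1cnc2c(Cl)ncnc21` gives 1200 nM while compound 3 `CCCCCCCCC[C@H](CCN=[N+]=[N-])n1cnc2c(Cl)ncnc21` gives 1220 nM as its value. Compound 2 thus lies within the scatter of both others, and the three cannot be ranked.

Compound 4 `CCCCCCCCCC(CCn1cc(-c2ccccc2)nn1)n1cnc2c(Cl)ncnc21` has not yet been measured. Its change from compound 2 is 4-phenyl-1H-1,2,3-triazol-1-yl in place of azido on a saturated chain carbon, three bonds along the chain from an aromatic nitrogen and it puts two aromatic rings where azido stood. Within the data shown here, the one measured step at this place is a 1.0-fold higher number from compound 1 to compound 2 (0.02 log units; within the scatter) for azido in place of hydroxy, which stayed within the scatter. The step of a 1.0-fold higher number from compound 2 to compound 3 (0.01 log units; within the scatter) involves only the fact that one of compounds 2 and 3 is drawn with a defined configuration and the other without, at the place where they differ and leaves that place untouched. Neither step brought in a ring, so they offer only weak guidance for a group this much larger.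

Resting on compound 2 at 1200 nM and on the step of a 1.0-fold higher number from compound 1 to compound 2 (0.02 log units; within the scatter) at this place, no shift beyond the scatter is expected. The estimated change is a 1.3-fold higher number from compound 2 to compound 4 (0.10 log units; within the scatter) and carries a wide margin. For compound 4 the expected value is 1500 nM within an estimated span of 500 nM to 5000 nM as its range.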

Compound 4, half-maximal inhibitory concentration: 9920 nM
Estimate against measurement, compound 4: 6.6-fold (0.82 log units) below; measured number outside the range, above it.
By their numbers in this assay, from the lowest: compounds 1, 2 and 3 (each within the scatter of the next); then compound 4.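

This position is not indifferent to what it carries: azido and hydroxy had given values within the scatter of each other, but 4-phenyl-1H-1,2,3-triazol-1-yl in place of azido brings an 8.3-fold higher number from compound 2 to compound 4 (0.92 log units; beyond the scatter) in this assay and clearly weakens inhibition. The same group in place of hydroxy brings an 8.6-fold higher number from compound 1 to compound 4 (0.94 log units; beyond the scatter) in this assay as well, so the loss appears against both small groups, neither of which has a ring. Nothing established for these compounds explains why this change weakens inhibition.

On these data alone, it remains open whether the triazole ring without its phenyl group would give a step of this size, or whether the phenyl group accounts for it. The compounds shown also do not tell how an amine or a carboxylic acid would read at this place on the chain.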